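Extending the amino nitrogen of compound 2

This account rests on a few compounds, and the source may have more. Where it says the series, first, only, none or still open, it means among the compounds named here.

Measured so far in a functional assay on K562 cells (Homo sapiens) for cytotoxicity, read by trypan blue exclusion, with a stated time of 96 h; on this read-out higher numbers stand for weaker inhibition and lower numbers for stronger inhibition:
- compound 1 `COc1ccc(CS(=O)(=O)/C=C/c2c(OC)cccc2OC)cc1N` gives 50 nM
- compound 2 `COc1cc(OC)c(/C=C/S(=O)(=O)Cc2ccc(OC)c(N)c2)c(OC)c1` gives 2.5 nM
- compound 3 `COc1cc(OC)c(/C=C/S(=O)(=O)Cc2ccc(Br)c(N)c2)c(OC)c1` gives 750 nM

Compound 2 holds the lowest number at 2.5 nM, and the other two values lie beyond the scatter from it. Compound 4 `COC(=O)CCNc1cc(CS(=O)(=O)/C=C/c2c(OC)cc(OC)cc2OC)ccc1OC` keeps the core of compound 2 and alters only the amino group: 2-(methoxycarbonyl)ethyl in place of hydrogen on a nitrogen on an aromatic ring. Among the measured compounds shown here, two measured steps bear on this only indirectly, and neither involves the nitrogen. Methoxy in place of hydrogen on an aromatic carbon gave a 20-fold lower number from compound 1 to compound 2 (1.30 log units; beyond the scatter), and bromo in place of methoxy on an aromatic carbon gave a 300-fold higher number from compound 2 to compound 3 (2.48 log units; beyond the scatter). Both steps are large, so single changes in this series can move the number widely. For the measured compounds named here, the data hold no example of substitution on the nitrogen. With compound 2 already at 2.5 nM, a higher number is expected in this assay, though a smaller rise than a 300-fold higher number from compound 2 to compound 3 (2.48 log units; beyond the scatter). The expected step is an 8.0-fold higher number from compound 2 to compound 4 (0.90 log units; beyond the scatter). For compound 4 the estimated value is 20 nM, with an expected range from 3 nM to 150 nM.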

Compound 4, half-maximal inhibitory concentration: 1000 nM
Compound 4: the middle estimate sits 50-fold (1.70 log units) below what was measured; the measured number lies above the stated range.
By their numbers in this assay, from the lowest: compound 2; then compound 1; then compounds 3 and 4 (each within the scatter of the next).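

Among the compounds shown here, this is the first step made at the nitrogen rather than on an aromatic carbon. In this assay, 2-(methoxycarbonyl)ethyl in place of hydrogen on this nitrogen gives a 400-fold higher number from compound 2 to compound 4 (2.60 log units; beyond the scatter), so the site does not accept this chain without a large change in the number, and the low value of compound 2 does not carry over to this extension. Nothing available accounts for the size of this rise.

One substituent on one nitrogen cannot show whether the rise follows from the ester, from the chain, or simply from replacing the hydrogen. A methyl group, a 2-carboxyethyl chain or a simple amide on the same nitrogen would each be a single change from compound 2 and would help separate these readings.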